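From 1H-indol-2-yl to benzyl on a shared core

A few compounds are considered here, and "the series" means these few. Any claim that something is new, unique, unknown or untested is made for them only; others in the source may bear on it.

In a functional assay on SW1573 cells (Homo sapiens) for inhibition, read by sulforhodamine B assay, with a stated time of 48 h (on this read-out higher numbers stand for weaker inhibition of growth and lower numbers for stronger inhibition of growth), compound 1 `O=C(/C=C/c1ccccc1)OCC1COCCOCCOCCOCCOCCO1` gives 48000 nM.
Compound 2 `CC(C)=CC1C(C(=O)OCC2COCCOCCOCCOCCOCCO2)C1(C)C` gives 54000 nM in this assay.
Compound 3 `O=C(CCCc1cc2ccccc2[nH]1)OCC1COCCOCCOCCOCCOCCO1` reaches only the limit > 100000 nM in this assay, which is a boundary of the measurement rather than a number.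

Compound 3 therefore stands at the limit of > 100000 nM in this assay, at which 1 of the 3 values shown sits, and no number places it against the other two. Compound 4 `O=C(CCCCc1ccccc1)OCC1COCCOCCOCCOCCOCCO1` differs from compound 3 by benzyl in place of 1H-indol-2-yl on a saturated chain carbon, three bonds along the chain from a carbonyl carbon. Among the compounds with values here, the only measured step, a 1.1-fold higher number from compound 1 to compound 2 (0.05 log units; within the scatter), alters a group on the carbonyl carbon and lies within the scatter; no measured step covers this change. Compound 1 and compound 2, which carry no 1H-indol-2-yl, both gave numbers. Compound 4 is expected to give a number near theirs; the expected step is an at least 1.3-fold lower number from compound 3 to compound 4 (0.12 log units; that floor lies within the scatter). The estimate for compound 4 is 75000 nM, between 35000 nM and 160000 nM.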

Compound 4, concentration for 50% growth inhibition: > 100000 nM
Compound 4: no number, only a limit; the forecaster's own chance of this, stated with the estimate: 40%; at least 1.3-fold (0.12 log units) between middle value and limit.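

In this assay compound 4, like compound 3, gives only a limit and not a number, so taking away 1H-indol-2-yl does not by itself bring back a measurable reading: the limit of > 100000 nM in this assay, at which 2 of the 4 values shown sit.

With 4-phenylbutyl on the carbonyl carbon, the comparisons give an at least 2.0-fold higher number from compound 1 to compound 4 (0.31 log units; beyond the scatter) and an at least 1.8-fold higher number from compound 2 to compound 4 (0.26 log units; that floor lies within the scatter). The step between the two limits cannot be read.

Still open, on these data alone, is whether the loss of a number follows the saturated chain or its aromatic end. A shorter chain ending in phenyl, or an amine at the chain end, could test this.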